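Compound 2 to compound 4: fluoro gives way to iodo

The source may report more compounds than this note shows. Statements on the series, on what has been measured and on what is new or still open speak of the compounds shown alone.

Compound 1 `O=C(CCc1cccc2c1B(O)OC2)Nc1ccccc1` gives 230 nM
Compound 2 `O=C(CCc1cccc2c1B(O)OC2)Nc1ccc(F)cc1` gives 440 nM
Compound 3 `CC(C)(C)c1ccc(NC(=O)CCc2cccc3c2B(O)OC3)cc1` gives 33000 nM

All three numbers come from a functional assay on MDA-MB-231 cells (Homo sapiens) for antiproliferative activity, read by MTT assay, with a stated time of 72 h; a higher number here means a weaker inhibitor, a lower number a stronger inhibitor. Compound 2 cannot be told apart from compound 1, since the measured change is a 1.9-fold higher number from compound 1 to compound 2 (0.28 log units; within the scatter). Compound 2 lies far under compound 3, with a change of a 75-fold higher number from compound 2 to compound 3 (1.88 log units; beyond the scatter).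

Compound 4 `O=C(CCc1cccc2c1B(O)OC2)Nc1cccc(I)c1` has not been measured. It carries 3-iodophenyl in place of 4-fluorophenyl on an amide-type nitrogen.

Two measured changes on this aromatic ring bear on that swap. Adding fluoro to compound 1 barely registers (see above), whereas adding tert-butyl gives a 140-fold higher number from compound 1 to compound 3 (2.16 log units; beyond the scatter). The ring therefore tolerates one substituent and not the other. For the measured compounds named here, no measured compound carries iodo, so these steps only loosely bound the outcome. A moderate upward step seems likelier than no change, and one as large as that of compound 3 seems unlikely. The expected step is a 2.7-fold higher number from compound 2 to compound 4 (0.44 log units; beyond the scatter) (an estimate with wide uncertainty). The estimated value for compound 4 is 1200 nM (expected range 250 nM to 8000 nM).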

Compound 4, half-maximal inhibitory concentration: 5300 nM
Estimate against measurement, compound 4: 4.4-fold (0.65 log units) below; low and high end bracket the measured number.
By their numbers in this assay, from the lowest: compounds 1 and 2 (each within the scatter of the next); then compound 4; then compound 3.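

In this assay, one iodo on the ring is enough for a large loss of activity, with a 23-fold higher number from compound 1 to compound 4 (1.36 log units; beyond the scatter) when it replaces hydrogen, and a 12-fold higher number from compound 2 to compound 4 (1.08 log units; beyond the scatter) when 3-iodophenyl replaces 4-fluorophenyl on the amide-type nitrogen. Tert-butyl is therefore no longer the only group on this aromatic ring tied to a large step, and the ring's tolerance of fluoro, with a 1.9-fold higher number from compound 1 to compound 2 (0.28 log units; within the scatter), does not extend to every substituent shown. No measured information on these compounds accounts for the size of the iodo step.

The change from 4-fluorophenyl to 3-iodophenyl alters both the atom on the ring and its place there, so these compounds cannot show how much of the step belongs to each. Going by these compounds, how the ring would respond to chloro, bromo, methoxy or an amine also stays open, and those groups would show whether fluoro or iodo is the exception among ring substituents.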